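Ethyl in place of vinyl at the far end of the chain

The source may hold more compounds than are shown below. What is called first, only, known or untested is meant among the compounds shown, and "the series" means these compounds.

Compound 1 `C=CCCCCCCCS(=O)(=O)/C=C/c1ccc(O)c(O)c1` — 6900 nM
Compound 2 `O=S(=O)(/C=C/c1ccc(O)c(O)c1)CC1CCCCC1` — 7500 nM
Compound 3 `O=S(=O)(/C=C/c1ccc(O)c(O)c1)CC1CCCO1` — 10500 nM

In a functional assay, read by fluorescence and spectrophotometry, with a stated time of 1 h (on this read-out higher numbers stand for an effect only at larger amounts of compound and lower numbers for an effect already at smaller amounts), compound 1 stands at the low end of three numbers that all fall within the scatter of one another. Compound 4 `CCCCCCCCCS(=O)(=O)/C=C/c1ccc(O)c(O)c1` is drawn from compound 1 by ethyl in place of vinyl on a saturated chain carbon, seven bonds along the chain from a sulfonyl sulfur. Going by the values given here, the one measured step, a 1.4-fold higher number from compound 2 to compound 3 (0.15 log units; within the scatter), alters the group on the carbon bound to the sulfonyl sulfur, not the far end of the chain, and it stays within the scatter; it bears on this change only by showing that the series tolerates variation in the saturated part. No step beyond the scatter is therefore expected in this assay, with a 1.1-fold lower number from compound 1 to compound 4 (0.03 log units; within the scatter) as the estimate. Compound 4 is expected to give 6500 nM, within 3000 nM to 14000 nM.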

Compound 4, half-maximal effective concentration: 7700 nM
For compound 4 the middle estimate is 1.2-fold (0.07 log units) below the measured one, within the range that was stated.
By their numbers in this assay, from the lowest: compounds 1, 2, 4 and 3 (each within the scatter of the next).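

In this assay the double bond of the vinyl end gives way to the saturated ethyl end with no change beyond the scatter (a 1.1-fold higher number from compound 1 to compound 4 (0.05 log units; within the scatter)). The earlier compounds varied only the group on the carbon bound to the sulfonyl sulfur, so this is the first reading at this place on the chain, and the double bond is shown not to be required there for the effect. No measurement on hand explains why the two ends read alike. The compounds shown leave open whether an amine, a carboxylic acid or a longer chain would be tolerated at this place.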